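The source may hold more compounds than are shown below. What is called first, only, known or untested is meant among the compounds shown, and "the series" means these compounds.

Measured in a functional assay on SW1573 cells (Homo sapiens) for inhibition, read by sulforhodamine B assay, with a stated time of 48 h; on this read-out lower numbers stand for stronger inhibition of growth and higher numbers for weaker inhibition of growth:
Compound 1, `O=C(/C=C/c1ccc(Cl)cc1Cl)c1ccccc1`, gives 12000 nM.
Compound 2, `CC(=O)OC/C(=C\C1CCCCC1)C(=O)c1ccccc1`, gives 19000 nM.

Compound 2 stands at the higher of these two numbers. For the measured compounds named here, its only neighbour is compound 1, whose number is somewhat lower, yet the gap between the two lies within the scatter of repeated measurements, so the two compounds cannot be told apart on this read-out.

Compound 3, `CC(=O)OC/C(=C\c1ccccc1F)C(=O)c1ccccc1`, has not yet been measured. It differs from compound 2 in a single place: 2-fluorophenyl in place of cyclohexyl on a double-bonded chain carbon bound to a double-bonded chain carbon. Going by the values given here, no step between two measured compounds matches this change, so the size of the expected step cannot be read off from a measured pair. What can be said is that compound 1 also carries an aromatic ring on its double-bonded chain and gives 12000 nM, a number within the scatter of compound 2. A small move toward stronger inhibition of growth is expected, a 2.1-fold lower number from compound 2 to compound 3 (0.32 log units; beyond the scatter), of a size that may not clearly exceed the scatter. Compound 3 is therefore estimated at 9000 nM, with a likely range from 2500 nM to 30000 nM.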

Compound 3, concentration for 50% growth inhibition: 6100 nM
Beside the measured number, compound 3's estimate is 1.5-fold (0.17 log units) above it; measured number inside the range.
By their numbers in this assay, from the lowest: compounds 3, 1 and 2 (each within the scatter of the next, the first and the last beyond it).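

Placing 2-fluorophenyl in place of cyclohexyl on a double-bonded chain carbon bound to a double-bonded chain carbon brings a 3.1-fold lower number from compound 2 to compound 3 (0.49 log units; beyond the scatter) and this is the first step in this assay that lies beyond the scatter, so what sits at this place does affect the read-out, though only modestly. The step swaps one six-membered ring for another, and the counts of hydrogen-bond donors and acceptors and the net charge stay the same, so the difference that matters does not show up in those counts. The change also alters two things at once, turning a non-aromatic ring into an aromatic one and adding a fluorine, and no measurement here accounts for the step.

The compounds shown leave open whether the aromatic ring alone carries the step or the fluorine is needed too, a question that a plain phenyl at this place would answer. Also open, as far as these compounds go, is how this place responds to a ring bearing an amine or a carboxylic acid, or to a simple longer carbon chain with no ring at all.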